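The compounds below may be only part of what the source reports. "The series", "measured", "known", "first", "only" and "open" are said of these compounds alone.

In an ADME assay on HEp-2 cells (Homo sapiens) for cytotoxicity, read by MTT assay, with a stated time of 72 h (on this read-out higher numbers stand for weaker inhibition and lower numbers for stronger inhibition), compound 1 (`C=CCOc1cc(C2=C(c3cc(OC)c(OC)c(OC)c3)C(=O)C(O)C2)ccc1OC`) reads > 100 ug/mL and this is a limit, not a number. Compound 2 (`COc1cc(C2=C(c3cc(C)c(OC)c(C)c3)C(OC(C)=O)CC2=O)cc(OC)c1OC`) reads > 100 ug/mL and this too is a limit. So far the series shows only the limit of > 100 ug/mL in this assay, at which 2 of the 2 values shown sit, and no number. Compound 3 (`COc1ccc(C2=C(c3cc(OC)c(OC)c(OC)c3)C(=O)C(O)C2)cc1F`) carries fluoro in place of allyloxy on an aromatic carbon, ortho to a methoxy group (fluoro in place of allyloxy on an aromatic carbon). Among the compounds with values here, no measured step covers this change, so only a tentative, modest move toward stronger inhibition in this assay is expected, with a limit reading still likely. The estimated move is an at least 1.2-fold lower number from compound 1 to compound 3 (0.09 log units; that floor lies within the scatter) in size. For compound 3 the expected value is 80 ug/mL within an estimated range of 20 ug/mL to 200 ug/mL for now.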

Compound 3, half-maximal inhibitory concentration: < 1 ug/mL
Compound 3: a limit, no number; the forecaster's own chance of this, stated with the estimate: 55%; middle value at least 80-fold (1.90 log units) away from the limit.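

Fluoro in place of allyloxy on this aromatic carbon, ortho to a methoxy group, gives an at least 100-fold lower number from compound 1 to compound 3 (2.00 log units; beyond the scatter) in this assay, so one place on the shared core can move the reading from one end of the assay's range to the other. Both readings behind this step are limits, not numbers. Among the compounds shown, only compound 3 sits at the low end: the limit of < 1 ug/mL in this assay, at which 1 of the 3 values shown sits.

Going by these compounds, it remains open whether the entry of fluoro or the loss of allyloxy drives the step. On these data alone, how chloro or an amine would read at this place also remains open.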